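Sulfanyl Replaces Formyl on the Silyl-Linked Phenyl Ring

This account rests on a few compounds, and the source may have more. Where it says the series, first, only, none or still open, it means among the compounds named here.

Of the compounds shown here, two have been measured. Compound 1 `CCN(C/C=C/C#CC(C)(C)C)Cc1cccc(OC[Si](C)(C)c2ccc(O)cc2)c1` gives 8000 nM in a functional assay on liver (Sus scrofa) for inhibition of squalene monooxygenase (Homo sapiens), using microsomes; on this read-out lower numbers stand for stronger inhibition and higher numbers for weaker inhibition. Going by the values given here, compound 2 `CCN(C/C=C/C#CC(C)(C)C)Cc1cccc(OC[Si](C)(C)c2ccc(C=O)cc2)c1` gives 100 nM in this assay, and the single measured step, an 80-fold lower number from compound 1 to compound 2 (1.90 log units; beyond the scatter), is the only guide available. Among the compounds with values here, compound 2 therefore stands at the lower of the two numbers, with compound 1 its only neighbour, separated by that large step.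

Compound 3 `CCN(C/C=C/C#CC(C)(C)C)Cc1cccc(OC[Si](C)(C)c2ccc(S)cc2)c1` is not yet measured. It differs from compound 2 in one place: sulfanyl in place of formyl on an aromatic carbon. Within the data shown here, the one step that bears on this change is the one from compound 1 to compound 2, in which the group carrying a hydrogen-bond donor gave way to formyl and the number fell sharply. Compound 3 reintroduces a group counted with one hydrogen-bond donor, so the step is expected to run the other way, though perhaps not all the way back. Compound 3 is expected to show a 15-fold higher number from compound 2 to compound 3 (1.18 log units; beyond the scatter), landing at an estimated 1500 nM, within a range of 300 nM to 8000 nM.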

Compound 3, half-maximal inhibitory concentration: 8000 nM
Estimate against measurement, compound 3: 5.3-fold (0.73 log units) below; the range from low to high includes it.
By their numbers in this assay, from the lowest: compound 2; then compounds 1 and 3 (each within the scatter of the next).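

In this assay, the position para to a large group proves sensitive a second time: sulfanyl in place of formyl gives an 80-fold higher number from compound 2 to compound 3 (1.90 log units; beyond the scatter), a loss that mirrors in reverse the gain in an 80-fold lower number from compound 1 to compound 2 (1.90 log units; beyond the scatter). Sulfanyl in place of hydroxy gives no change at the digits printed from compound 1 to compound 3 (within the scatter), so these two groups cannot be told apart on this read-out, and among the three groups shown, only formyl, which brings no hydrogen-bond donor and does bring a double bond outside the aromatic ring, stands at the low number. No measurement shown here accounts for the difference between formyl and the other two groups, so the result stays an observation without a stated cause.

Formyl differs from sulfanyl in its heavy atoms, its double bond and its count of hydrogen-bond donors, and the three compounds cannot show which of these differences goes with the low number. From the compounds shown here alone, whether formyl is singular at this position also stays open, and groups such as acetyl, methoxy or nitrile on the same aromatic carbon would bear on both questions.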